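Trifluoromethyl for Methyl, Tested on a Second Core

The compounds below may be only part of what the source reports. "The series", "measured", "known", "first", "only" and "open" are said of these compounds alone.

Compound 1 `CCN(c1nc(C)cc(C)n1)c1ccc(N(C)C)cc1C` and compound 3 `CCN(c1nc(C)cc(C)n1)c1ccc(N(C)C)cc1C(F)(F)F` share one core and differ in a single place: trifluoromethyl in place of methyl on an aromatic carbon. In an assay on isolated protein for binding affinity to corticotropin-releasing factor receptor 1 (Homo sapiens) (a higher number here means a weaker inhibitor, a lower number a stronger inhibitor), compound 1 gives 54 nM, and compound 3 gives 68 nM; the step of a 1.3-fold higher number from compound 1 to compound 3 (0.10 log units; within the scatter). Compound 2 `CCCN(CCC)c1nc(C)nc(N(CC)c2ccc(N(C)C)cc2C)n1` is built on a different core; how the two cores differ is not broken down here. In this assay compound 2 gives 7 nM, the lowest of the three numbers and beyond the scatter from each of the others. Compound 4 `CCCN(CCC)c1nc(C)nc(N(CC)c2ccc(N(C)C)cc2C(F)(F)F)n1` has not yet been measured. It stands to compound 2 as compound 3 stands to compound 1: trifluoromethyl in place of methyl on an aromatic carbon. The surroundings of the changed group are described in the same words for both pairs, so this is the same kind of change carried onto another core. The expected step here, a 1.3-fold higher number from compound 2 to compound 4 (0.11 log units; within the scatter), rests on the earlier step of a 1.3-fold higher number from compound 1 to compound 3 (0.10 log units; within the scatter) having stayed within the scatter. Compound 4 is therefore estimated at 9 nM, with a likely range from 4 nM to 22 nM.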

Compound 4, inhibition constant: 6 nM
Compound 4: the middle estimate sits 1.5-fold (0.18 log units) above what was measured, within the range that was stated.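

In this assay, trifluoromethyl in place of methyl on an aromatic carbon gives a 1.2-fold lower number from compound 2 to compound 4 (0.07 log units; within the scatter), so on the core of compound 2 the two numbers cannot be told apart, just as on the core of compound 1. The two steps agree with each other: the same change on two cores in this assay, a 1.3-fold higher number (0.10 log units; within the scatter) from compound 1 to compound 3 and a 1.2-fold lower number (0.07 log units; within the scatter) from compound 2 to compound 4, 1.5-fold (0.17 log units) apart, within the scatter of two such steps. This shows that the change made no readable difference on either of these two cores in this one assay, but two pairs do not show that it would do the same on any other core, and they do not explain why the numbers hold.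

The compounds shown leave open how other groups at this same place, such as a chlorine atom, a methoxy group or an ethyl chain, would compare with methyl and trifluoromethyl. They also leave open whether the swap would still make no readable difference if the dimethylamino group were replaced by another amine.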